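The source may hold more compounds than are shown below. What is called first, only, known or untested is meant among the compounds shown, and "the series" means these compounds.

Compound 1 `COc1cccc(Cc2ccnn(CC(=O)Nc3ccc(Br)cc3)c2=O)c1` gives 14600 nM in an assay on HL-60 cells for agonist activity at N-formyl peptide receptor 3 (Homo sapiens), read by calcium flux; on this read-out lower numbers stand for an effect already at smaller amounts and higher numbers for an effect only at larger amounts of compound. Compound 2 `COc1cccc(Cc2cc(C3CCCCC3)nn(CC(=O)Nc3ccc(Br)cc3)c2=O)c1` returns only a limit of the assay, > 50000 nM. Compound 3 `COc1cccc(Cc2cc(-c3ccccc3)nn(CC(=O)Nc3ccc(Br)cc3)c2=O)c1` likewise returns only a limit, > 50000 nM. Both steps away from compound 1 lie beyond the scatter, an at least 3.4-fold higher number from compound 1 to compound 2 (0.53 log units; beyond the scatter) and an at least 3.4-fold higher number from compound 1 to compound 3 (0.53 log units; beyond the scatter), while a step that the two limits leave unreadable from compound 2 to compound 3 because both compounds sit at the limit of > 50000 nM in this assay, at which 2 of the 3 values shown sit. Compound 3 thus stands at the limit, with only compound 1 giving a readable number. Compound 4 `COc1cccc(Cc2cc(-c3ccccc3)nn(CC(=O)Nc3ccc(F)cc3)c2=O)c1` differs from compound 3 by fluoro in place of bromo on an aromatic carbon. Among the compounds with values here, none of the measured steps touches this change; they vary the group on an aromatic carbon of the shared core and say nothing about the halogen. Compound 4 is therefore expected to stay at the limit, with a step that the limit leaves unreadable from compound 3 to compound 4 not beyond the scatter. Compound 4 is estimated at 60000 nM, with a range from 20000 nM to 200000 nM.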

Compound 4, half-maximal effective concentration: > 50000 nM
Compound 4: a limit, no number; the forecaster's own chance of this, stated with the estimate: 75%; the middle value does not contradict the limit.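

No new step can be read between compound 3 and compound 4, since both return only a limit: the limit of > 50000 nM in this assay, at which 3 of the 4 values shown sit. Whether fluoro in place of bromo shifts the response in this assay stays open among the compounds shown.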